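The source may hold more compounds than are shown below. What is called first, only, known or untested is meant among the compounds shown, and "the series" means these compounds.

Compound 1 `C=CCn1ncc2c(C)nc(C)n2c1=O` in a functional assay for inhibition, with Homo sapiens as the target (on this read-out lower numbers stand for stronger inhibition and higher numbers for weaker inhibition), gives 73000 nM. Compound 2 `C=CCn1ncc2c(CCC)ncn2c1=O` is reported in this assay only as a limit, > 48000 nM. Compound 3 `C=CCn1ncc2c(C)nc(Cc3ccccc3)n2c1=O` is likewise reported in this assay only as a limit, > 48000 nM.

Compound 3 therefore stands at the edge of this assay rather than at a number, and it shares that position with one other compound, as the limit of > 48000 nM in this assay, at which 2 of the 3 values shown sit, records. The step to compound 4 `C=CCn1ncc2c(C)ncn2c1=O` is hydrogen in place of benzyl on an aromatic carbon. Among the measured compounds shown here, the only measured step that bears on it, a step that the limit leaves unreadable from compound 1 to compound 3, is itself unreadable. For the measured compounds named here, compound 1 is the one compound with a number, and that number sits only modestly inside the readable range. Compound 4 is expected at 70000 nM, within 20000 nM to 250000 nM, which means an expected step that the limit leaves unreadable from compound 3 to compound 4.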

Compound 4, half-maximal inhibitory concentration: > 48000 nM
Compound 4: no number, only a limit; the forecaster's own chance of this, stated with the estimate: 55%; the middle value does not contradict the limit.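

Among the compounds shown here, compound 4 is reported only as a limit, > 48000 nM, so no step linking it to compound 1, compound 2 or compound 3 can be read. The compounds shown leave open whether any of these changes to the shared core shifts inhibition at all.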